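The source may hold more compounds than are shown below. What is called first, only, known or untested is meant among the compounds shown, and "the series" means these compounds.

Compound 1 `C=c1[nH]c(=O)/c(=C/c2ccc(OC)cc2)[nH]c1=O` gives > 20000 nM as a limit
Compound 2 `C=c1[nH]c(=O)/c(=C/c2ccc(C(=O)OC)cc2)[nH]c1=O` gives > 20000 nM as a limit
Compound 3 `C=c1[nH]c(=O)/c(=C/c2ccc(C(F)(F)F)cc2)[nH]c1=O` gives > 20000 nM as a limit

In a functional assay on Huh7.5.1 cells (Homo sapiens) for cytotoxicity, read by MTT assay, with a stated time of 72 h (on this read-out higher numbers stand for lower toxicity in this test and lower numbers for higher toxicity in this test), compound 3 stands at > 20000 nM as a limit of the assay, not a number. The whole set offers only the limit of > 20000 nM in this assay, at which 3 of the 3 values shown sit, as its evidence. Compound 4 `C=c1[nH]c(=O)/c(=C/c2ccc(-c3ccccc3)cc2)[nH]c1=O` differs from compound 3 by phenyl in place of trifluoromethyl on an aromatic carbon. Three measured steps exchange a group in the same way: a step that the two limits leave unreadable from compound 1 to compound 2 and a step that the two limits leave unreadable from compound 1 to compound 3 and a step that the two limits leave unreadable from compound 2 to compound 3 all lack a readable size. No step beyond the scatter is therefore expected in this assay and the estimated change is a number no higher from compound 3 to compound 4 (the limit leaves the size open) in size. Compound 4 is expected at 20000 nM within an estimated range of 9000 nM to 40000 nM and will probably be reported as a limit again.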

Compound 4, half-maximal cytotoxic concentration: > 20000 nM
Compound 4 was reported as a limit; the forecaster's own chance of this, stated with the estimate: 80%; the middle value lies on the limit itself.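

Compound 4 is again reported only as a limit, so its steps from compound 1, compound 2 and compound 3 cannot be read in this assay. The compounds shown leave open at what concentration any of them becomes toxic in this test: the limit of > 20000 nM in this assay, at which 4 of the 4 values shown sit.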